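The compounds below may be only part of what the source reports. "The series", "measured", "known", "first", "only" and "open" are said of these compounds alone.

Measured so far:
- compound 1 `COc1cc(NC(C)CCCNC(=O)Nc2ccc(C(F)(F)F)cc2)c2ncccc2c1`, 8300 nM
- compound 2 `COc1cc(NC(C)CCCNC(=O)NNC(=O)Nc2cccc(C(F)(F)F)c2)c2ncccc2c1`, 4900 nM
- compound 3 `COc1cc(NC(C)CCCNC(=O)NNC(=O)Nc2ccc(F)cc2)c2ncccc2c1`

In a functional assay on HeLa cells (Homo sapiens) for inhibition, read by MTT assay, with a stated time of 72 h (on this read-out lower numbers stand for stronger inhibition and higher numbers for weaker inhibition), compound 3 gives only a limit, >= 250000 nM. Compound 2 and compound 1 lie within the usual scatter of each other, and compound 3 reached only a limit.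

The unmeasured compound 4 `COc1cc(NC(C)CCCNC(=O)NNC(=O)Nc2ccc(Cl)cc2)c2ncccc2c1` differs from compound 2 in one place: 4-chlorophenyl in place of 3-(trifluoromethyl)phenyl on an amide-type nitrogen. For the measured compounds named here, the closest precedent is an at least 51-fold higher number from compound 2 to compound 3 (1.70 log units; beyond the scatter), where a halogen-bearing phenyl also replaced the 3-(trifluoromethyl)phenyl; the related step of an at least 30-fold higher number from compound 1 to compound 3 (1.47 log units; beyond the scatter) points the same way. A sizeable weakening is therefore expected, a 10-fold higher number from compound 2 to compound 4 (1.01 log units; beyond the scatter), though with wide uncertainty. Compound 4 is estimated at 50000 nM, between 8000 nM and 250000 nM.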

Compound 4, half-maximal inhibitory concentration: 120000 nM
For compound 4 the middle estimate is 2.4-fold (0.38 log units) below the measured one; measured number inside the range.
By their numbers in this assay, from the lowest: compounds 2 and 1 (each within the scatter of the next); then compound 4. At a limit, above all of these: compound 3.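

With 4-chlorophenyl on this amide-type nitrogen, the loss now has a real size rather than a limit, a 24-fold higher number from compound 2 to compound 4 (1.39 log units; beyond the scatter), and the comparison with the other active compound agrees, a 14-fold higher number from compound 1 to compound 4 (1.16 log units; beyond the scatter). Chloro in place of fluoro on the aromatic carbon also changes the result, with an at least 2.0-fold lower number from compound 3 to compound 4 (0.31 log units; beyond the scatter). Compound 3 still stands only as a limit: the limit of >= 250000 nM in this assay, at which 1 of the 4 values shown sits.

Open, going by these compounds, is whether the loss follows the swap of trifluoromethyl for a halogen or the group's place on the ring. A 3-chlorophenyl or a 4-(trifluoromethyl)phenyl here would separate the two, and a 4-aminophenyl would test a group without halogen.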